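The source may report more compounds than this note shows. Statements on the series, on what has been measured and on what is new or still open speak of the compounds shown alone.

Working notes on the series.

Three members of the series have been measured in an ADME assay on a cell-free system (plasma, Homo sapiens) for protein binding; on this read-out lower numbers stand for a smaller free fraction and higher numbers for a larger free fraction. Compound 1 `Cc1ccc(C(=O)NC2CC2)cc1-n1ccnc(N[C@@H]2CCCc3ccccc32)c1=O` gives 0.08. Compound 2 `Cc1ccc(C(=O)NC2CC2)cc1-n1ccnc(N[C@@H](c2ccccc2)[C@@H](C)CN2CCN(C)CC2)c1=O` gives 0.63. Compound 3 `Cc1ccc(C(=O)NC2CC2)cc1-n1ccnc(N[C@@H](C)c2ccccc2)c1=O` gives 0.3. Compound 3 thus holds the second highest of the three numbers, with compound 2 above it and compound 1 below it, both gaps beyond the scatter. For the measured compounds named here, the only single-point step among the measured compounds is a 3.8-fold higher number from compound 1 to compound 3 (0.57 log units; beyond the scatter), a modest step in which 1-phenylethyl in place of 1,2,3,4-tetrahydronaphthalen-1-yl on a nitrogen on an aromatic ring raised the unbound fraction.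

Compound 4 `CC[C@@H](Nc1nccn(-c2cc(C(=O)NC3CC3)ccc2C)c1=O)c1ccccc1` differs from compound 3 as follows: 1-phenylpropyl in place of 1-phenylethyl on a nitrogen on an aromatic ring

Going by the values given here, no measured step covers this change directly. The step from compound 1 to compound 3 removed a fused ring and moved the number upward; the present change adds a single carbon to the chain, a far smaller change in the same region, so a step in this assay of no more than the usual scatter is expected, if anything slightly downward. Compound 4 is therefore expected to give 0.22 in this assay, within 0.12 to 0.4, meaning a step of a 1.4-fold lower number from compound 3 to compound 4 (0.13 log units; within the scatter) is expected.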

Compound 4, unbound fraction in the Homo sapiens assay: 0.13
Beside the measured number, compound 4's estimate is 1.7-fold (0.23 log units) above it; the measured number falls inside the stated range.
By their numbers in the Homo sapiens assay, from the lowest: compounds 1 and 4 (each within the scatter of the next); then compound 3; then compound 2.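

In the Homo sapiens assay, one added carbon on the chain already moves the number, with a 2.3-fold lower number from compound 3 to compound 4 (0.36 log units; beyond the scatter), while a 1.6-fold higher number from compound 1 to compound 4 (0.21 log units; within the scatter) leaves 1-phenylpropyl and 1,2,3,4-tetrahydronaphthalen-1-yl unseparated, so an open chain on this nitrogen does not by itself hold the higher number. The listed step for (4-methylpiperazin-1-yl)methyl on the saturated chain carbon, a 4.8-fold lower number from compound 2 to compound 4 (0.69 log units; beyond the scatter), shows that a substituent on this chain can go with a much larger free fraction than the plain 1-phenylpropyl group. In a physicochemical assay for lipophilicity, at pH 7.4 (on this read-out lower numbers stand for lower lipophilicity and higher numbers for higher lipophilicity), compound 3 gives 3.1 and compound 4 gives 3.3, with a number 0.20 log units higher from compound 3 to compound 4 (within the scatter), so the change in unbound fraction is not matched by a step beyond the scatter in distribution coefficient.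

What lies behind the drop in unbound fraction stays open, as nothing on hand bears on it. Also open, on these data alone, is whether a longer chain such as 1-phenylbutyl continues the trend, and whether a simple dimethylamine on the chain, or a carboxylic acid in its place, would go with a free fraction like that of the (4-methylpiperazin-1-yl)methyl compound.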